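This account rests on a few compounds, and the source may have more. Where it says the series, first, only, none or still open, it means among the compounds named here.

Measured compounds:
compound 1, `CCCCCCCCc1ccc(OCC(=O)Cn2cnnn2)cc1`, 22%
compound 2, `CCCCCCCCc1ccc(OCC(=O)Cn2nnc(-c3cccc(S(=O)(=O)N(C)C)c3)n2)cc1`, 9%

In an ADME assay on S9 fraction from liver (Rattus norvegicus) for metabolic stability, read by LC-MS, using NADPH, with a stated time of 30 min (on this read-out higher numbers stand for a more stable compound and lower numbers for a less stable compound), compound 1 gives 22%, and compound 2 gives 9%. Of the two numbers, compound 2 stands lowest; its nearest neighbour is compound 1, whose value lies higher by a gap that goes beyond the usual scatter of this assay.

The step under consideration leads from compound 2 to compound 3, `CCCCCCCCc1ccc(OCC(=O)Cn2nnc(CCC(=O)O)n2)cc1`. The change is 2-carboxyethyl in place of 3-(dimethylsulfamoyl)phenyl on an aromatic carbon. In the words of the count, 2-carboxyethyl takes the place of 3-(dimethylsulfamoyl)phenyl on an aromatic carbon of a five-membered aromatic ring with four nitrogen atoms, the ring atom that bears the large group sitting between two ring nitrogen atoms.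

Within the data shown here, no step between measured compounds is available, so the size can only be guessed from what compound 1 and compound 2 show. Compound 1, which carries no group at this position, gives 22%, while compound 2 gives 9%; the compound with the smaller substituent is the more stable of the pair. For compound 3 an upward step is therefore expected, estimated as a number 21 percentage points higher from compound 2 to compound 3 (beyond the scatter), a change that would lie beyond the scatter. Compound 3 is expected to give about 30% in this assay, with a range from 12% to 55%.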

Compound 3, percent of the compound remaining: < 5%
Compound 3: a limit, no number (the forecaster's own chance of this, stated with the estimate: 0%); at least 25 percentage points between middle value and limit.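

In this assay compound 3 gives < 5%, which is a limit and not a number: the limit of < 5% in this assay, at which 1 of the 3 values shown sits. Replacing 3-(dimethylsulfamoyl)phenyl with 2-carboxyethyl on this aromatic carbon gives a number at least 4 percentage points lower from compound 2 to compound 3 (that floor lies within the scatter), so losing the six-membered aromatic ring and taking a group with fewer heavy atoms does not bring the value back toward that of compound 1, at 22%. The position therefore tolerates neither of the two groups shown any better than the bare aromatic carbon of compound 1, and group size alone does not order the three compounds, with compound 3 going against the trend that compound 1 and compound 2 suggested.

The compounds shown leave open whether the carboxylic acid or the two-carbon chain that carries it goes with the low reading, which a methyl ester, a primary amide or a plain propyl group at this carbon could separate. They also leave open how far compound 3 really lies under compound 2, and how much of the loss in all three compounds comes from the shared core rather than from the group at this position.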